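The source may report more compounds than this note shows. Statements on the series, on what has been measured and on what is new or still open speak of the compounds shown alone.

Measured so far in a functional assay on U-937 cells (Homo sapiens) for antiproliferative activity, read by MTT assay, with a stated time of 24 h; a lower number here means a stronger inhibitor of growth, a higher number a weaker inhibitor of growth:
- compound 1 `Cc1ccc(NC(=O)C2(C)CCc3c(C)c(O)c(C)c(C)c3O2)cc1NC(=O)c1cnoc1C`: > 30000 nM, a limit
- compound 2 `Cc1cc(NC(=O)Nc2cccc(Cl)c2)ccc1NC(=O)c1cnoc1C`: > 30000 nM, a limit

Neither compound has a number, only a limit: the limit of > 30000 nM in this assay, at which 2 of the 2 values shown sit. Where compound 2 stands is therefore known only as a limit, and its true value is not defined. For the measured compounds named here, the two compounds also differ in more than one place, so no measured step is available to size a change.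

The next compound is compound 3 `Cc1cc(NC(=O)Nc2ccccc2F)ccc1NC(=O)c1cnoc1C`, still unmeasured in this assay. Its difference from compound 2 is 2-fluorophenyl in place of 3-chlorophenyl on an amide-type nitrogen. In words, 2-fluorophenyl stands in place of 3-chlorophenyl on an amide-type nitrogen, and the rest of the structure is unchanged.

Going by the values given here, with no measured step to go on, no step beyond the scatter is expected in this assay, and no direction is favoured. The estimate rests on compound 2, whose limit is > 30000 nM. The expected change is a number no higher from compound 2 to compound 3 (the limit leaves the size open). A limit is again the most likely report. For compound 3 the estimated value is 30000 nM, with an expected range of 12000 nM to 60000 nM.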

Compound 3, concentration for 50% growth inhibition: > 30000 nM
Compound 3: only a limit was reported (the forecaster's own chance of this, stated with the estimate: 80%); the middle value sits exactly at the limit.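

In this assay, compound 2 and compound 3 are both reported only as limits, and no step can be read between them. The compounds shown leave open what true value any of them has in this assay, and whether 2-fluorophenyl in place of 3-chlorophenyl alters growth inhibition at all: the limit of > 30000 nM in this assay, at which 3 of the 3 values shown sit.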